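A few compounds are considered here, and "the series" means these few. Any claim that something is new, unique, unknown or untested is made for them only; others in the source may bear on it.

Compound 1 `O=C(CCc1ccc(Cl)cc1)C(=O)NCCCCc1ccccc1` gives 200 nM in an assay on HEK-293T cells for inhibition of phospholipase A and acyltransferase 5 (Homo sapiens), with stated times of 30 min and 20 min; on this read-out lower numbers stand for stronger inhibition and higher numbers for weaker inhibition.
Compound 2 `CCNC(=O)C(=O)CCc1ccc(Cl)cc1` gives 1000 nM in this assay.

Of these two numbers, compound 2 stands highest; its nearest neighbour is compound 1, and the measured step between them is a 5.0-fold higher number from compound 1 to compound 2 (0.70 log units; beyond the scatter). Compound 3 `O=C(CCc1ccc(Cl)cc1)C(=O)N1CCCCC1` has not yet been measured in this assay. It differs from compound 2 in one place: piperidin-1-yl in place of ethylamino on a carbonyl carbon.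

Within the data shown here, only one measured step is available to judge this change, a 5.0-fold higher number from compound 1 to compound 2 (0.70 log units; beyond the scatter), and it concerns a different position, a saturated chain carbon rather than the carbonyl carbon. It shows that a larger group on the amide side of the shared core went with a lower number. Among the measured compounds shown here, the change to compound 3 likewise enters a larger group on that side, but it also removes the amide hydrogen, and no measured pair shows what that removal does. A modest downward step in this assay is therefore expected, with wide uncertainty.

Compound 3 is expected to give about 500 nM, within a range from 150 nM to 2000 nM. This corresponds to an estimated step of a 2.0-fold lower number from compound 2 to compound 3 (0.30 log units; within the scatter).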

Compound 3, half-maximal inhibitory concentration: > 10000 nM
Compound 3 gave a limit, no number (the forecaster's own chance of this, stated with the estimate: 5%); at least 20-fold (1.30 log units) between middle value and limit.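

On the carbonyl carbon, piperidin-1-yl in place of ethylamino gives an at least 10-fold higher number from compound 2 to compound 3 (1.00 log units; beyond the scatter), so in this assay this change moves the number sharply upward, not downward as the earlier step on the saturated chain carbon might have suggested. The result for compound 3 is a limit of the assay and not a number: the limit of > 10000 nM in this assay, at which 1 of the 3 values shown sits.

This position therefore does not simply accept a larger group, and the link between size and a lower number seen with compound 1 and compound 2 does not carry over to compound 3; the change here swaps an open chain with one hydrogen-bond donor for a six-membered ring with none, and both differences arrive in the same step.

The compounds shown cannot say whether the ring or the missing amide hydrogen goes with the weaker inhibition, and a pair built on the same core would be needed to separate them: cyclohexylamino keeps the amide hydrogen and carries a six-membered ring, while dimethylamino has no amide hydrogen and no ring. From the compounds shown here alone, since the value for compound 3 is a limit, the full size of its step also stays open.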